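The compounds below may be only part of what the source reports. "The series", "measured", "known", "first", "only" and "open" are said of these compounds alone.

The study concerns ester derivatives built on a shared bicyclic core, varied at the aromatic acid portion and in the saturation of the core. Compound 1, `COc1cccc(C(=O)Oc2cc3c(cc2C)[C@@H](C(C)C)CC=C3C)c1`, carries a 3-methoxyphenyl ester on the partly saturated core; in a functional assay on K562 cells (Homo sapiens) for antiproliferative activity, read by sulforhodamine B assay, with a stated time of 48 h, tested at 50 uM (a higher number here means more inhibition at the concentration tested (going by the name of the read-out), a lower number less inhibition), compound 1 is reported as "not active" (no number reported), with no number given. Compound 2, `Cc1cc2c(C(C)C)ccc(C)c2cc1OC(=O)c1cccc(C(F)(F)F)c1`, on the fully aromatic core with a trifluoromethyl group, is likewise reported in this assay as "not active" (no number reported). Compound 3, `COc1ccc(C(=O)Oc2cc3c(C)ccc(C(C)C)c3cc2C)cc1`, also on the fully aromatic core but with a methoxy group, gives 88.6% in this assay. Compound 1 thus stands with compound 2 among the entries without a number, while compound 3 alone has a measured inhibition. The unmeasured compound 4, `CC1=CC[C@H](C(C)C)c2cc(C)c(OC(=O)c3cccc(Cl)c3)cc21`, differs from compound 1 by chloro in place of methoxy on an aromatic carbon. For the measured compounds named here, no step between measured compounds is available to size this change, so any shift in this assay is expected to be modest, in either direction, and may well stay within the scatter. Compound 4 is therefore estimated to give 20%, with a range from 0% to 55%.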

Compound 4, a percentage reported as inhibition, at one concentration (the size of the read-out at that concentration, not a potency): "not active" (no number reported)
No number was reported for compound 4; no gap can be computed for the estimate.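

In this assay, for the compounds shown here, neither compound 1 nor compound 4 has a number, so no step between them can be read. Nothing shown offers an explanation for this result. The compounds shown leave open how far 3-methoxyphenyl to 3-chlorophenyl changes inhibition on the partly saturated core.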